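The compounds below may be only part of what the source reports. "The series", "measured", "known", "first", "only" and "open" are said of these compounds alone.

Measured so far:
compound 1 `CCc1nc(I)c2n1CCN([C@@H](C(=O)NC)c1ccccc1)C2CCc1ccc(C(F)(F)F)cc1` — in a functional assay on CHO cells for antagonist activity at Orexin/Hypocretin receptor type 1 (Homo sapiens), read by FLIPR and calcium flux (on this read-out higher numbers stand for weaker inhibition and lower numbers for stronger inhibition), compound 1 gives 717 nM
compound 2 `CCc1nc(C(=O)N(C)C)c2n1CCN([C@@H](C(=O)NC)c1ccccc1)C2CCc1ccc(C(F)(F)F)cc1` — in this assay compound 2 gives 344 nM

Among the compounds with values here, compound 2 stands at the lower of the two numbers; the only step known, a 2.1-fold lower number from compound 1 to compound 2 (0.32 log units; beyond the scatter), is modest but beyond the scatter. Compound 3 `CCc1nc(C)c2n1CCN([C@@H](C(=O)NC)c1ccccc1)C2CCc1ccc(C(F)(F)F)cc1` is not yet measured. It differs from compound 2 by methyl in place of dimethylcarbamoyl on an aromatic carbon. Within the data shown here, no measured step bears directly on this change: the single known step swaps iodo for dimethylcarbamoyl at the same aromatic carbon, and compound 1 with iodo sits above compound 2. Methyl, like iodo, brings no hydrogen-bond acceptor, so compound 3 is expected to land between the two known numbers, leaning toward compound 1, which is a step of a 1.7-fold higher number from compound 2 to compound 3 (0.24 log units; within the scatter) in this assay. The estimate for compound 3 is 600 nM, with a range from 250 nM to 1500 nM.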

Compound 3, half-maximal inhibitory concentration: 10000 nM
Compound 3: middle estimate off by 17-fold (1.22 log units), on the low side, and the stated range ends below it.
By their numbers in this assay, from the lowest: compound 2; then compound 1; then compound 3.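

In this assay, this aromatic carbon proves far more sensitive than the earlier pair showed: a 29-fold higher number from compound 2 to compound 3 (1.46 log units; beyond the scatter), and a 14-fold higher number from compound 1 to compound 3 (1.14 log units; beyond the scatter). Methyl therefore does not act as a stand-in for iodo here, and compound 1 and compound 2 both keep far stronger inhibition than compound 3, despite the different groups they carry at this position. Nothing available accounts for the drop.

Going by these compounds, it remains open whether the weak inhibition is specific to methyl or extends to other groups on this carbon, and a chlorine atom, a nitrile or an amine would help to separate those readings. On these data alone, it also remains open whether a monomethyl amide or a primary amide would match or improve on dimethylcarbamoyl.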